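Removing the Benzyl Ring: Compound 4 Expected in This Assay

The compounds below may be only part of what the source reports. "The series", "measured", "known", "first", "only" and "open" are said of these compounds alone.

Measured compounds and their values in a functional assay on CHO cells for activation of 5-hydroxytryptamine receptor 1D (Homo sapiens), read by GTPgammaS binding; a lower number here means a smaller maximal response, a higher number a larger maximal response:
compound 1, `c1ccc2c(c1)CCC2NC1CCN(CCCc2c[nH]c3ccc(-n4cnnc4)cc23)CC1`, gives 68%;
compound 2, `COC[C@H](NC1CCN(CCCc2c[nH]c3ccc(-n4cnnc4)cc23)CC1)c1ccccc1`, gives 93%;
compound 3, `CN(Cc1ccccc1)CC1CCN(CCCc2c[nH]c3ccc(-n4cnnc4)cc23)CC1`, gives 93%.

Compound 3 stands level with compound 2 at the digits given, the two together highest of the three numbers; the step of no change at the digits printed from compound 2 to compound 3 (within the scatter) lies within the scatter, while the step of a number 25 percentage points higher from compound 1 to compound 3 (beyond the scatter) lies beyond it. Compound 4, `CC(C)=CCN(C)C1CCN(CCCc2c[nH]c3ccc(-n4cnnc4)cc23)CC1`, differs from compound 3 in one place: methyl(3-methylbut-2-en-1-yl)amino in place of (benzyl(methyl)amino)methyl on a saturated ring carbon.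

Going by the values given here, none of the measured steps covers this change. The steps of a number 25 percentage points higher from compound 1 to compound 2 (beyond the scatter) and a number 25 percentage points higher from compound 1 to compound 3 (beyond the scatter) both involve exchange of the group on the saturated ring carbon and both were modest, while no change at the digits printed from compound 2 to compound 3 (within the scatter) showed no change. All three measured compounds keep a six-membered aromatic ring of carbon only in this region; compound 4 has no ring there, so the data give no direct guide. Given that two of three measured compounds reach a high maximal response, compound 4 is expected to remain near that level, with a step of a number 8 percentage points lower from compound 3 to compound 4 (within the scatter) estimated to be small or none beyond the scatter. Compound 4 is therefore estimated at 85%, within a range from 65% to 100%.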

Compound 4, largest response reached (reported as efficacy), in percent of the reference or control that the assay uses: 115%
The estimate for compound 4 lay 30 percentage points below the measured number; the measured number lies above the stated range.
By their numbers in this assay, from the lowest: compound 1; then compounds 2 and 3 (each within the scatter of the next); then compound 4.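

In this assay, going by these compounds alone, a ring of the kind kept by the earlier compounds proves unnecessary for a high maximal response at this saturated ring carbon: methyl(3-methylbut-2-en-1-yl)amino, which has no ring, gives a number 22 percentage points higher from compound 3 to compound 4 (beyond the scatter) in place of (benzyl(methyl)amino)methyl and a number 22 percentage points higher from compound 2 to compound 4 (beyond the scatter) in place of (2-methoxy-1-phenylethyl)amino. Within the data shown here, the level shared by compound 2 and compound 3 is therefore not a ceiling for this position, and compound 4 stands highest of the four, with a number 47 percentage points higher from compound 1 to compound 4 (beyond the scatter) as the only large step among them. No measurement shown here accounts for this rise.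

The change removes the ring, adds a double bond, shortens the group by the heavy atoms counted and moves the nitrogen onto the saturated ring carbon all at once, so the compounds shown cannot assign the higher response to any one of these features. Going by these compounds, it remains open whether a saturated 3-methylbutyl chain on the same methylamino nitrogen, or a benzyl group attached directly through that nitrogen, would reach the response of compound 4 in this assay or fall back towards that of compound 3.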